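The source may report more compounds than this note shows. Statements on the series, on what has been measured and on what is new or still open speak of the compounds shown alone.

In a functional assay on QGY cells (Homo sapiens) for cytotoxicity, read by MTT assay, with a stated time of 48 h (on this read-out higher numbers stand for weaker inhibition and lower numbers for stronger inhibition), compound 1 `COc1cc([C@@H]2C[C@]2(CO)C(=O)Nc2ccccc2Cl)cc(OC)c1OC` gives 15700 nM, and compound 3 `CCOC(=O)[C@]1(C(=O)Nc2ccccc2Cl)C[C@@H]1c1cc(OC)c(OC)c(OC)c1` gives 34700 nM, the higher of these two exact numbers. Compound 2 `CCOC(=O)[C@@]1(C(=O)Nc2ccccc2Cl)C[C@@H]1c1cc(OC)c(OC)c(OC)c1` gives only a limit, > 100000 nM. Compound 4 `CCOC(=O)[C@]1(C(=O)Nc2ccccc2Cl)C[C@H]1c1cc(OC)c(OC)c(OC)c1` differs from compound 3 in one place: the two compounds have the same atoms and bonds and differ only in configuration as drawn: 1 of 2 stereo elements differ; a stereocentre at a saturated ring carbon is drawn R in compound 3 and S in compound 4. For the measured compounds named here, the one measured step of this kind is an at least 2.8-fold lower number from compound 2 to compound 3 (0.45 log units; beyond the scatter), and its full size stays open because of the limit of > 100000 nM in this assay, at which 1 of the 3 values shown sits. It bears on the new change through (the fact that compounds 2 and 3 differ only in the configuration as drawn). A single switch of configuration can therefore move the number beyond the scatter, so a step of similar size is expected, probably towards weaker inhibition, though the direction is uncertain. The expected change is a 1.3-fold higher number from compound 3 to compound 4 (0.11 log units; within the scatter). For compound 4 the estimated value is 45000 nM, with an expected range from 10000 nM to 100000 nM.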

Compound 4, half-maximal inhibitory concentration: 28000 nM
Compound 4: the middle estimate sits 1.6-fold (0.21 log units) above what was measured; the measured number falls inside the stated range.
By their numbers in this assay, from the lowest: compounds 1, 4 and 3 (each within the scatter of the next, the first and the last beyond it). At a limit, above all of these: compound 2.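

In this assay, inverting one stereocentre at a saturated ring carbon does not always move the number: there is a 1.2-fold lower number from compound 3 to compound 4 (0.09 log units; within the scatter) and this lies within the scatter, unlike the earlier single inversion. The mirror-image pair does separate, with an at least 3.5-fold lower number from compound 2 to compound 4 (0.55 log units; beyond the scatter) and a full size left open by the limit on compound 2. Ethoxycarbonyl in place of hydroxymethyl gives a 1.8-fold higher number from compound 1 to compound 4 (0.25 log units; within the scatter) and this too lies within the scatter. As far as these compounds go, how the other stereoisomers of compound 1 behave stays open, as does what a carboxylic acid or an amine on that ring carbon would give.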